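Removing the fluoroethyl group from an oxime ether

A few compounds are considered here, and "the series" means these few. Any claim that something is new, unique, unknown or untested is made for them only; others in the source may bear on it.

Compound 2, `C/C(=N\OCCF)c1ccc(Sc2cc(F)cc(C3CCOCC3)c2)cc1`: 40 nM
Compound 3, `C/C(=N\O)c1cccc(Sc2cc(F)cc(C3CCOCC3)c2)c1`: 2910 nM
Compound 1, `OC1O[C@H](CO/N=C2\CCc3cc(Sc4cc(F)cc(C5CCOCC5)c4)ccc32)[C@H](O)[C@H](O)[C@H]1O`: a limit, > 2500 nM

Of the compounds shown here, three share the same diaryl thioether core and have been tested in a functional assay (blood) for inhibition, with Homo sapiens as the target; on this read-out higher numbers stand for weaker inhibition and lower numbers for stronger inhibition. Compound 2 gives the lowest of the two numbers, at 40 nM. The nearest number belongs to compound 3, whose value of 2910 nM lies far weaker, well beyond the scatter. Compound 1 gives no number, only a limit of > 2500 nM; this is the limit of > 2500 nM in this assay, at which 1 of the 3 values shown sits.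

The step of interest runs from compound 2 to compound 4, `C/C(=N\O)c1ccc(Sc2cc(F)cc(C3CCOCC3)c2)cc1`, which has not yet been tested in this assay. The change is hydrogen in place of 2-fluoroethyl on an oxygen. Going by the values given here, compound 3 likewise carries hydrogen on an oxygen next to the double-bonded nitrogen and gives 2910 nM, but no single step joins compound 3 to either compound 2 or compound 4, so its weak value is only a hint.

On this basis compound 4 is expected to give a weaker number than compound 2, by a step estimated at a 15-fold higher number from compound 2 to compound 4 (1.18 log units; beyond the scatter) in this assay. The estimate for compound 4 is 600 nM, within a range from 150 nM to 2500 nM.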

Compound 4, half-maximal inhibitory concentration: 80 nM
The estimate for compound 4 lay 7.5-fold (0.88 log units) above the measured number, outside the stated range (below it).
By their numbers in this assay, from the lowest: compounds 2 and 4 (each within the scatter of the next); then compound 3.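

In this assay the oxygen whose other neighbour is the double-bonded nitrogen takes hydrogen in place of 2-fluoroethyl with little consequence for the read-out: a 2.0-fold higher number from compound 2 to compound 4 (0.30 log units; within the scatter). The 2-fluoroethyl chain is therefore not needed for a low number on this core, and the weak value of compound 3, 2910 nM, shows that hydrogen on this oxygen does not by itself go with a high number, since compound 4 carries the same hydrogen and stays within the scatter of compound 2. Nothing shown here gives a cause for this outcome.

On these data alone, what remains open is whether a methyl group, a longer chain such as 3-fluoropropyl, or a chain ending in an amine or a carboxylic acid would be taken on this oxygen as readily as hydrogen and 2-fluoroethyl are. Compound 1 gives only a limit of the assay, > 2500 nM, and it differs from compound 2 in more than one place, so it sets no size for larger groups on this oxygen.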